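A few compounds are considered here, and "the series" means these few. Any claim that something is new, unique, unknown or untested is made for them only; others in the source may bear on it.

Series notes. In an ADME assay on MCF-10A cells (Homo sapiens) for cytotoxicity, read by MTT assay, with a stated time of 48 h (on this read-out lower numbers stand for stronger inhibition and higher numbers for weaker inhibition), compound 1, `COc1cc(C#N)ccc1OCc1nnc(-c2ccc(F)cc2)o1`, gives only a limit, > 100000 nM. Compound 2, `COc1cc(C#N)ccc1OCc1nnc(-c2ccc(Cl)cc2)o1`, gives 89500 nM in this assay. The change from compound 1 to compound 2 is chloro in place of fluoro on an aromatic carbon; it made an at least 1.1-fold lower number from compound 1 to compound 2 (0.04 log units; that floor lies within the scatter). Compound 3, `Fc1ccc(-c2nnc(COc3ccc(-c4nnco4)cc3)o2)cc1`, carries a different core; the difference between the two cores is not broken down here. In this assay compound 3 also gives only a limit, > 100000 nM. Among the compounds with values here, two of the three values so far sit at the limit of > 100000 nM in this assay, at which 2 of the 3 values shown sit. Compound 4, `Clc1ccc(-c2nnc(COc3ccc(-c4nnco4)cc3)o2)cc1`, is not yet measured; it carries the same change as before, (chloro in place of fluoro on an aromatic carbon), at a place described in the same words. For compound 4 a step of an at least 1.0-fold lower number from compound 3 to compound 4 (0.02 log units; that floor lies within the scatter) is expected, beside the earlier at least 1.1-fold lower number from compound 1 to compound 2 (0.04 log units; that floor lies within the scatter). Compound 4 is estimated at 95000 nM, within 50000 nM to 200000 nM, with a fair chance that this assay again reports only a limit.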

Compound 4, half-maximal inhibitory concentration: > 100000 nM
Compound 4 was reported as a limit; the forecaster's own chance of this, stated with the estimate: 55%; middle value at least 1.0-fold (0.02 log units) from the limit.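

In this assay, within the data shown here, compound 3 and compound 4 both give only limits, so no step between them can be read: the limit of > 100000 nM in this assay, at which 3 of the 4 values shown sit. From the compounds shown here alone, what the 4-fluorophenyl to 4-chlorophenyl change does on the core of compound 3 stays open.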